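This account rests on a few compounds, and the source may have more. Where it says the series, first, only, none or still open, it means among the compounds named here.

Notes on the series, read in an ADME assay on MRC5 cells (Homo sapiens) for inhibition, with a stated time of 72 h; a lower number here means that less compound is needed, a higher number that more compound is needed for the effect. Compound 1 (`CCCCCNC(=O)c1n[nH]cc1NC(=O)c1c(OC)cccc1OC`) gives > 50000 nM, which is a limit and not a number. Compound 2 (`COc1cccc(OC)c1C(=O)Nc1c[nH]nc1C(=O)NCc1ncccc1C`) gives > 50000 nM, also a limit and not a number. Compound 2 therefore has no exact position on the scale, and the evidence so far is the limit of > 50000 nM in this assay, at which 2 of the 2 values shown sit. Among the compounds with values here, the only measured step is a step that the two limits leave unreadable from compound 1 to compound 2.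

Compound 3 (`COc1cccc(OC)c1C(=O)Nc1c[nH]nc1C(=O)NC1CCC(C)CC1`) keeps the shared core and changes the group on the amide-type nitrogen: 4-methylcyclohexyl in place of (3-methylpyridin-2-yl)methyl on an amide-type nitrogen. In words, 4-methylcyclohexyl stands in place of (3-methylpyridin-2-yl)methyl. The measured step also concerns this side of the amide, but it offers no size to carry over. On the strength of the limit of > 50000 nM in this assay, at which 2 of the 2 values shown sit, no step beyond the scatter is expected in this assay, and no direction can be expected either. The expected step is a step that the limit leaves unreadable from compound 2 to compound 3. A reading of compound 3 at the limit again would be the likeliest outcome. For compound 3 the estimated value is 60000 nM, with an expected range of 25000 nM to 150000 nM.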

Compound 3, half-maximal effective concentration: 45000 nM
Compound 3: the middle estimate sits 1.3-fold (0.12 log units) above what was measured; low and high end bracket the measured number.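

In this assay, within the data shown here, compound 3 gives 45000 nM, the first exact number, so a group on the amide-type nitrogen now has a position on the scale. The change to 4-methylcyclohexyl, a ring of carbon only, amounts to an at least 1.1-fold lower number from compound 2 to compound 3 (0.04 log units; that floor lies within the scatter), and the same group in place of pentyl amounts to an at least 1.1-fold lower number from compound 1 to compound 3 (0.04 log units; that floor lies within the scatter); both steps are floors, and neither can be read as a real change on this evidence. The exact number therefore adds a reference point but no established effect of the group, and the series shown remains tied to the top of the scale: the limit of > 50000 nM in this assay, at which 2 of the 3 values shown sit.

On these data alone, how far the true values of compound 1 and compound 2 lie from that of compound 3 stays unknown, as their steps give floors only. Also open, as far as these compounds go, is whether a piperidin-4-yl amine, a carboxylic acid or a plain cyclohexyl group in place of 4-methylcyclohexyl on the amide-type nitrogen would give a number clearly apart from that of compound 3.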